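The source may hold more compounds than are shown below. What is called first, only, known or untested is meant among the compounds shown, and "the series" means these compounds.

Measured compounds:
- compound 1, `Cc1ccc(Nc2nc(-c3cc(C(=O)Nc4ccccn4)no3)cs2)cc1`: 2900 nM
- compound 2, `CCOC(=O)c1cc(-c2coc(Nc3ccc(C)cc3)n2)on1`: 9100 nM

Compound 2 stands highest of the two numbers in a physicochemical assay for solubility, read by LC-MS, measured as kinetic solubility, with a stated time of 4 h; on this read-out lower numbers stand for lower solubility and higher numbers for higher solubility; its nearest neighbour is compound 1, whose value sits a step below that lies beyond the usual scatter. For the measured compounds named here, no step between the two measured compounds is computed here, since they differ in more than one place.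

Compound 3, `Cc1ccc(Nc2nc(-c3cc(C(=O)Nc4ccccn4)no3)co2)cc1`, is not yet measured. Its change from compound 2 is (pyridin-2-yl)amino in place of ethoxy on a carbonyl carbon, in words (pyridin-2-yl)amino in place of ethoxy on a carbonyl carbon. Going by the values given here, with no single-change step in hand, the direction rests on the two points that exist: compound 2 gives 9100 nM and compound 1 gives 2900 nM. The expectation for compound 3 is a step downward from compound 2, of about a 3.0-fold lower number from compound 2 to compound 3 (0.48 log units; beyond the scatter), beyond the scatter but not by much. Compound 3 is estimated at 3000 nM, with a range of 1000 nM to 9000 nM.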

Compound 3, solubility: 24000 nM
Beside the measured number, compound 3's estimate is 8.0-fold (0.90 log units) below it, and the stated range ends below it.
By their numbers in this assay, from the lowest: compound 1; then compound 2; then compound 3.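

In this assay, for the compounds shown here, the change from ethoxycarbonyl to (pyridin-2-yl)carbamoyl gives the first single-place step, a 2.6-fold higher number from compound 2 to compound 3 (0.42 log units; beyond the scatter), so the larger group on this carbonyl carbon, with its ring and hydrogen-bond donor, comes with a modest rise rather than a fall in the number. The same (pyridin-2-yl)carbamoyl group does not fix the value: compound 1 gives 2900 nM, whereas compound 3 gives 24000 nM, and these two compounds differ only elsewhere in the core. Nothing at hand accounts for the step.

Which part of the entering group goes with the rise remains open. Phenylamino or a simple dimethylamino group on the same carbonyl carbon would separate the ring nitrogen from the amide hydrogen, and a carboxylic acid there would extend the comparison.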